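Compound 2 to compound 4: methyl to 4-methoxybenzyl

A few compounds are considered here, and "the series" means these few. Any claim that something is new, unique, unknown or untested is made for them only; others in the source may bear on it.

Measured in a functional assay on cells (Cancer cell lines, Homo sapiens) for cytotoxicity, with a stated time of 48 h; on this read-out lower numbers stand for stronger inhibition of growth and higher numbers for weaker inhibition of growth:
- compound 1 `COc1cc(/C=C2/C(=O)N(C)c3ccc(O)cc32)cc(OC)c1OC`: 4300 nM
- compound 2 `COc1ccc2c(c1)/C(=C\c1cc(OC)c(OC)c(OC)c1)C(=O)N2C`: 2600 nM
- compound 3 `COc1cc(/C=C2\C(=O)N(Cc3ccc(Cl)cc3)c3ccccc32)cc(OC)c1OC`: 2200 nM

Compound 2, at 2600 nM, has both other measured compounds within the scatter of it, so the three numbers form one narrow band. The next compound is compound 4 `COc1ccc(CN2C(=O)/C(=C/c3cc(OC)c(OC)c(OC)c3)c3cc(OC)ccc32)cc1`. The change is 4-methoxyphenyl in place of hydrogen on a saturated chain carbon bound to an amide-type nitrogen in a ring, or methyl to 4-methoxybenzyl when cut one bond further out.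

Among the measured compounds shown here, no measured step covers this place. For the measured compounds named here, the only measured step, a 1.7-fold lower number from compound 1 to compound 2 (0.22 log units; within the scatter), concerns an oxygen on an aromatic ring and stays within the scatter. Going by the values given here, the values therefore give no direction for the change, and the narrow band in this assay is the only guide. No shift beyond the scatter is expected. The expected step is a 1.2-fold lower number from compound 2 to compound 4 (0.07 log units; within the scatter). For compound 4 the estimated value is 2200 nM, with an expected range of 700 nM to 6500 nM.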

Compound 4, concentration for 50% growth inhibition: 1900 nM
Compound 4: middle estimate off by 1.2-fold (0.06 log units), on the high side, within the range that was stated.
By their numbers in this assay, from the lowest: compounds 4, 3, 2 and 1 (each within the scatter of the next, the first and the last beyond it).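

Among the compounds shown here, this is the first step read at the substituent on the amide-type nitrogen in the ring: in this assay, 4-methoxyphenyl in place of hydrogen on the saturated chain carbon gives a 1.4-fold lower number from compound 2 to compound 4 (0.14 log units; within the scatter). The position thus takes 4-methoxybenzyl in place of methyl with no shift beyond the scatter, so for this pair, the added aromatic ring leaves the growth-inhibition number in the same band. No measured evidence bearing on this step is available, and its size remains a bare observation.

Open, going by these compounds, is whether an amine or a carboxylic acid on this substituent, or a longer chain between the nitrogen and the aromatic ring, would move the number beyond the scatter. Also open, on these data alone, is how the shared core reads with the amide hydrogen in place of any substituent there.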